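The source may report more compounds than this note shows. Statements on the series, on what has been measured and on what is new or still open speak of the compounds shown alone.

Measured so far in a functional assay on MKN-45 cells (Homo sapiens) for cytotoxicity, read by MTT assay, with a stated time of 72 h; on this read-out lower numbers stand for stronger inhibition and higher numbers for weaker inhibition: compound 2 `COc1cc2c(Oc3ccc(NC(=O)c4cn(-c5ccc(Br)cc5)nn4)cc3F)ccnc2cc1OCCCN1CCCC1` gives 120 nM; compound 3 `COc1cc2c(Oc3ccc(NC(=O)c4cn(-c5c(C)cccc5C)nn4)cc3F)ccnc2cc1OCCCN1CCCC1` gives 3490 nM; compound 1 `COc1cc2c(Oc3ccc(NC(=O)c4cn(-c5ccccc5C)nn4)cc3F)ccnc2cc1OCCCN1CCCC1` gives "not determined" (no result reported).

Going by the values given here, compound 3 stands highest of the two numbers, the weaker inhibitor of the pair; the one measured step, a 29-fold higher number from compound 2 to compound 3 (1.46 log units; beyond the scatter), separates it from compound 2 and concerns the group on the aromatic nitrogen. Compound 4 `COc1cc2c(Oc3ccc(NC(=O)c4cn(-c5c(C)cccc5C)nn4)cc3F)ccnc2cc1OCCCN1CCC(C)CC1` carries a different change, (4-methylpiperidin-1-yl in place of pyrrolidin-1-yl on a saturated chain carbon, three bonds along the chain from an oxygen on an aromatic ring). Among the compounds with values here, no measured pair differs in this way, so the data give no guide to its size or direction. The expectation is therefore a step of a 1.1-fold lower number from compound 3 to compound 4 (0.04 log units; within the scatter), nothing beyond the scatter. Compound 4 is estimated to give 3200 nM, expected to lie between 1000 nM and 10000 nM.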

Compound 4, half-maximal inhibitory concentration: 4310 nM
Compound 4: middle estimate off by 1.3-fold (0.13 log units), on the low side, within the range that was stated.
By their numbers in this assay, from the lowest: compound 2; then compounds 3 and 4 (each within the scatter of the next).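

Going by these compounds alone, the step of a 1.2-fold higher number from compound 3 to compound 4 (0.09 log units; within the scatter) in this assay is the first reading at this position: with the 2,6-dimethylphenyl group unchanged, a six-membered ring bearing a methyl group replaces the five-membered ring, and the two numbers lie within the scatter of each other. Nothing measured here gives a reason for this result.

As far as these compounds go, whether 4-methylpiperidin-1-yl would read the same in a compound carrying the 4-bromophenyl group remains open. So does the outcome with morpholin-4-yl, a primary amine or a carboxylic acid on this chain, or with a longer chain.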